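Swapping an aryl carbonyl for a short chain

The source may hold more compounds than are shown below. What is called first, only, known or untested is meant among the compounds shown, and "the series" means these compounds.

Measured so far:
compound 1 `O=C(Nc1cc(C(F)(F)F)cc(C(F)(F)F)c1)C1CCc2ccccc2N1C(=O)c1cccc(Cl)c1`: 560 nM
compound 2 `O=C(Nc1ccccc1C(F)(F)F)C1CCc2ccccc2N1`: 39300 nM

In a functional assay on NUGC-3 cells (Homo sapiens) for cytotoxicity, read by sulforhodamine B assay, with a stated time of 72 h (on this read-out higher numbers stand for weaker inhibition of growth and lower numbers for stronger inhibition of growth), compound 1 gives 560 nM, the lower of the two numbers. Compound 2 gives 39300 nM in this assay, a gap well beyond the scatter, though the two differ in more than one place, so no single change can be read from them. Compound 3 `CCC(=O)N1c2ccccc2CCC1C(=O)Nc1cc(C(F)(F)F)cc(C(F)(F)F)c1` is not yet measured. It differs from compound 1 by ethyl in place of 3-chlorophenyl on a carbonyl carbon. Among the measured compounds shown here, no measured step of this kind exists here, so the expectation is a moderate move toward weaker growth inhibition. The step of a 3.6-fold higher number from compound 1 to compound 3 (0.55 log units; beyond the scatter) is estimated from that reasoning alone. Compound 3 is expected to give about 2000 nM in this assay, within 500 nM to 8000 nM.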

Compound 3, concentration for 50% growth inhibition: 7220 nM
Estimate against measurement, compound 3: 3.6-fold (0.56 log units) below; the measured number falls inside the stated range.
By their numbers in this assay, from the lowest: compound 1; then compound 3; then compound 2.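

In this assay ethyl in place of 3-chlorophenyl on the carbonyl carbon gives a 13-fold higher number from compound 1 to compound 3 (1.11 log units; beyond the scatter) and so shows that the group at this position matters strongly for growth inhibition. Compound 1 and compound 3 differ only here, and both keep the carbonyl, so the step belongs to this one change. Nothing measured here gives a reason for the step. Going by these compounds, it remains open whether the ring or the chlorine accounts for the step. An unsubstituted phenyl or a longer chain such as butyl on the same carbonyl would help separate the two.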